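The source may report more compounds than this note shows. Statements on the series, on what has been measured and on what is new or still open speak of the compounds shown alone.

Compound 1 `Cc1nc(-c2ccccn2)nc(N)c1Cl`: 85300 nM
Compound 2 `Cc1nc(-c2ccccn2)nc(NCCC2CCCCC2)c1Cl`: 49500 nM

In an ADME assay on L6 cells (Rattus norvegicus) for cytotoxicity (on this read-out higher numbers stand for weaker inhibition and lower numbers for stronger inhibition), compound 2 stands at 49500 nM, within the usual scatter of compound 1 at 85300 nM. The next compound to be tested, compound 3 `Cc1nc(-c2ccccn2)nc(NCC2CCOC2)c1Cl`, differs from compound 2 by having oxolan-3-yl in place of cyclohexylmethyl on a saturated chain carbon bound to a nitrogen on an aromatic ring. Within the data shown here, the two measured values show no step to build on, so no change beyond the scatter is expected in this assay. The estimated step is small, a 1.4-fold higher number from compound 2 to compound 3 (0.15 log units; within the scatter). For compound 3 the expected value is 70000 nM, with an estimated range from 30000 nM to 150000 nM.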

Compound 3, half-maximal inhibitory concentration: 125000 nM
Beside the measured number, compound 3's estimate is 1.8-fold (0.25 log units) below it; the range from low to high includes it.
By their numbers in this assay, from the lowest: compounds 2, 1 and 3 (each within the scatter of the next, the first and the last beyond it).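

In this assay, a step beyond the scatter now appears at this position: oxolan-3-yl in place of cyclohexylmethyl gives a 2.5-fold higher number from compound 2 to compound 3 (0.40 log units; beyond the scatter). Against the hydrogen on the nitrogen, (oxolan-3-yl)methyl gives a 1.5-fold higher number from compound 1 to compound 3 (0.17 log units; within the scatter), so compound 1 and compound 3 cannot be told apart. No measured evidence explains either step. Ring size and the ring oxygen changed together from compound 2 to compound 3, so the compounds shown cannot separate the two. Going by these compounds, how a cyclopentylmethyl group, or a chain ending in an amine, would read at this position remains open.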